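Removing the ring methyl from compound 2

The source may hold more compounds than are shown below. What is called first, only, known or untested is meant among the compounds shown, and "the series" means these compounds.

In a functional assay on DU-145 cells (Homo sapiens) for cytotoxicity (a lower number here means a stronger inhibitor of growth, a higher number a weaker inhibitor of growth), compound 1 `COc1ccc(C2=C(c3ccc(SC)cc3)CC3CCCN3C2=O)cc1OC(=O)C1CCCN1C(=O)OC(C)(C)C` gives 5000 nM and compound 2 `COc1ccc(C2=C(c3ccc(SC)cc3)CC3CCCN3C2=O)cc1C` gives 900 nM as its value. Compound 2 holds the lower of the two numbers, and its gap to compound 1 lies beyond the scatter. Compound 3 `COc1ccc(C2=C(c3ccc(SC)cc3)CC3CCCN3C2=O)cc1` has yet to be measured in this assay as the next point. Its structure has hydrogen in place of methyl on an aromatic carbon ortho to a methoxy group, so 4-methoxy-3-methylphenyl becomes 4-methoxyphenyl. Among the compounds with values here, no measured pair isolates this change, so the expectation is tentative. A modest rise in the number is expected, one that may stay close to the scatter. The estimated step is a 1.6-fold higher number from compound 2 to compound 3 (0.19 log units; within the scatter) in this measure. For compound 3 the expected value is 1400 nM with an estimated range from 400 nM to 5000 nM overall.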

Compound 3, concentration for 50% growth inhibition: 900 nM
Compound 3: middle estimate off by 1.6-fold (0.19 log units), on the high side, within the range that was stated.
By their numbers in this assay, from the lowest: compounds 2 and 3 (each within the scatter of the next); then compound 1.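

Working notes on the aromatic carbon ortho to a methoxy group: in this assay, hydrogen in place of methyl gives no change at the digits printed from compound 2 to compound 3 (within the scatter), so this methyl can be dropped without a change that can be read in this measure. The 4-methoxyphenyl of compound 3 therefore serves as the simpler reference for this part of the series, and compound 3, at 900 nM, can be set against compound 1, which carries the larger ester at this carbon and gives 5000 nM. No measurement shown here explains the result.

The compounds shown leave open how small groups other than methyl behave at this carbon, such as a hydroxyl, an amine or a fluorine atom. They also leave open whether an ethyl group or a longer chain sits as readily there as hydrogen and methyl do.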